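Swapping methoxy for methylamino on a shared core

The source may report more compounds than this note shows. Statements on the series, on what has been measured and on what is new or still open speak of the compounds shown alone.

Compound 1 `COc1ccc(-c2ccn(CCC(C)C)c(=O)c2C#N)cc1` was tested in a functional assay on CHO cells for positive allosteric modulation of metabotropic glutamate receptor 2 (Homo sapiens), read by scintillation counting and GTPgammaS binding, with a stated time of 30 min (a higher number here means that more compound is needed for the effect, a lower number that less compound is needed), where compound 1 gives 1150 nM. Among the three measured compounds this is the second highest number. Compound 2 `COc1ccc(-c2ccn(CCC(C)C)c(=O)c2C#N)cc1F` carries fluoro in place of hydrogen on an aromatic carbon and gives 1170 nM; the step of a 1.0-fold higher number from compound 1 to compound 2 (0.01 log units; within the scatter) stays within the scatter. Compound 3 `COc1ccc(-c2ccn(CCC(C)C)c(=O)c2C#N)cc1OC` carries methoxy in place of that same hydrogen and gives 260 nM; the step of a 4.4-fold lower number from compound 1 to compound 3 (0.65 log units; beyond the scatter) is modest but real, and so is a 4.5-fold lower number from compound 2 to compound 3 (0.65 log units; beyond the scatter).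

Compound 4 `CNc1ccc(-c2ccn(CCC(C)C)c(=O)c2C#N)cc1` differs from compound 1 in another way: methylamino in place of methoxy on an aromatic carbon. Among the compounds with values here, none of the measured steps touches this group; all of them vary a different aromatic carbon, while the methoxy group is kept throughout. The earlier steps therefore give no direct guide, and a methylamino replacement has no precedent among these compounds. Within the data shown here, with no measured step of this kind, the expectation is a number close to that of compound 1, with no change beyond the scatter, though the uncertainty is wide. Compound 4 is estimated at 1000 nM, with a range from 350 nM to 3000 nM, which corresponds to an expected step of a 1.2-fold lower number from compound 1 to compound 4 (0.06 log units; within the scatter).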

Compound 4, half-maximal effective concentration: 460 nM
Beside the measured number, compound 4's estimate is 2.2-fold (0.34 log units) above it, and the stated range covers the measured number.
By their numbers in this assay, from the lowest: compounds 3 and 4 (each within the scatter of the next); then compounds 1 and 2 (each within the scatter of the next).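

The earlier compounds shown here varied a different aromatic carbon and kept the methoxy group, so they could not show whether the group para to a large group matters in this assay. This change shows that it does: the step is a 2.5-fold lower number from compound 1 to compound 4 (0.40 log units; beyond the scatter), modest in size but real. The swap is small on paper, since both groups have 2 heavy atoms, no ring and no net charge, and the listed differences are nitrogen for oxygen and 1 hydrogen-bond donor for methylamino against 0 for methoxy, yet that is enough to move the number; nothing measured here explains the shift.

A single replacement cannot show whether the nitrogen itself or the hydrogen on it is what counts, and a dimethylamino group, which keeps the nitrogen but has no such hydrogen, or a plain amine in the same place would help to separate the two. Going by these compounds, it also remains open whether methylamino and the added methoxy group of compound 3 would combine their effects in one molecule, or whether one would cancel the other.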